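The source may report more compounds than this note shows. Statements on the series, on what has been measured and on what is new or still open speak of the compounds shown alone.

Measured so far:
compound 1 `COc1ccc(F)cc1CNCCCNc1ccnc2cc(CCc3ccccc3)ccc12` — 4240 nM
compound 2 `COc1cccc(Oc2ccc3c(NCCCNCc4cccc(OC)c4O)ccnc3c2)c1` — 5300 nM

In an ADME assay on HepG2 cells (Homo sapiens) for cytotoxicity, read by luminescence, CellTiter-Glo and ATP content, with a stated time of 72 h (a higher number here means that more compound is needed for the effect, a lower number that less compound is needed), compound 1 gives 4240 nM, the lowest of the two numbers. Compound 2 gives 5300 nM, which lies within the scatter of compound 1, so no order between the two is drawn. Compound 3 `COc1ccc(F)cc1CNCCCNc1ccnc2cc(-c3cccc4ccccc34)ccc12` is not yet measured and differs from compound 1 in one place: naphthalen-1-yl in place of phenethyl on an aromatic carbon. Within the data shown here, no step between measured compounds bears on this change, so the expectation rests on compound 1 alone. In this assay a small step toward a lower number is expected for compound 3, hardly beyond the scatter. Compound 3 is estimated at 3000 nM, with a range of 1200 nM to 8000 nM. The expected step is a 1.4-fold lower number from compound 1 to compound 3 (0.15 log units; within the scatter).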

Compound 3, half-maximal effective concentration: 16000 nM
Beside the measured number, compound 3's estimate is 5.3-fold (0.73 log units) below it; the whole stated range lies below it.
By their numbers in this assay, from the lowest: compounds 1 and 2 (each within the scatter of the next); then compound 3.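

In this assay the aromatic carbon that carries phenethyl in compound 1 proves sensitive to its substituent: naphthalen-1-yl in that place gives a 3.8-fold higher number from compound 1 to compound 3 (0.58 log units; beyond the scatter) and so more compound is needed for the effect. Among these compounds, compounds 1 and 2 alone offered no step at this place. Nothing on hand gives a reason for this step.

Open, going by these compounds, is whether a plain phenyl on this carbon would read like compound 1 or like compound 3, which would separate the second fused ring from the loss of the chain. On these data alone, how a longer chain such as 3-phenylpropyl would read also stays open.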